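Trimming a dichlorophenyl amide to an acetyl group

A few compounds are considered here, and "the series" means these few. Any claim that something is new, unique, unknown or untested is made for them only; others in the source may bear on it.

Measured so far:
Compound 1, `COc1cc(/C=C/C(=O)c2cccc(NC(=O)c3ccc(Cl)cc3)c2)ccc1O`: 66%
Compound 2, `COc1cc(/C=C/C(=O)c2cccc(NC(=O)c3ccco3)c2)ccc1O`: 100%
Compound 3, `COc1cc(/C=C/C(=O)c2cccc(NC(=O)c3ccc(Cl)c(Cl)c3)c2)ccc1O`: 45%

In a functional assay on HUVEC cells (Homo sapiens) for inhibition, tested at 10 ug/mL (on this read-out higher numbers stand for a stronger effect at the one concentration tested and lower numbers for a weaker effect), compound 3 stands lowest of the three, with compound 1 nearest and compound 2 furthest above it. Compound 4, `COc1cc(/C=C/C(=O)c2cccc(NC(C)=O)c2)ccc1O`, differs from compound 3 as follows: methyl in place of 3,4-dichlorophenyl on a carbonyl carbon. Within the data shown here, two measured steps bear on this change. The step of a number 55 percentage points lower from compound 2 to compound 3 (beyond the scatter) shows that a 3,4-dichlorophenyl in place of furan-2-yl on the carbonyl carbon cost much, and the step of a number 21 percentage points lower from compound 1 to compound 3 (beyond the scatter) shows that adding the second chloro alone cost a modest amount. Taking the whole 3,4-dichlorophenyl away for a methyl is therefore expected to raise the number in this assay by a large step, a number 27 percentage points higher from compound 3 to compound 4 (beyond the scatter). Compound 4 is expected to give about 72%, within 45% to 98%.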

Compound 4, a percentage reported as inhibition, at one concentration (the size of the read-out at that concentration, not a potency): 32%
The estimate for compound 4 lay 40 percentage points above the measured number, and the stated range ends above it.
By their numbers in this assay, from the lowest: compound 4; then compound 3; then compound 1; then compound 2.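

In this assay, trimming the 3,4-dichlorophenyl to methyl on this carbonyl carbon did not recover the number but gave a number 13 percentage points lower from compound 3 to compound 4 (beyond the scatter), so the loss seen on adding the second chloro does not mean that less of the aryl group is better. The other steps, a number 34 percentage points lower from compound 1 to compound 4 (beyond the scatter) and a number 68 percentage points lower from compound 2 to compound 4 (beyond the scatter), place methyl below all three ring-bearing amides shown, with no exception among these four compounds.

Nothing measured here explains these differences. On these data alone, it remains open whether a thiophene ring, a cyclopropyl group or a longer alkyl chain on this carbonyl carbon would come nearer to compound 2 or to compound 4.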